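This account rests on a few compounds, and the source may have more. Where it says the series, first, only, none or still open, it means among the compounds named here.

Measured so far in a functional assay on KB cells (Homo sapiens) for inhibition; on this read-out higher numbers stand for weaker inhibition and lower numbers for stronger inhibition:
compound 1, `OCC(CO)OCn1c(Cl)nc2c(Cl)c(Cl)ccc21`, gives > 100000 nM.
compound 2, `CNc1nc2cc(Cl)c(Cl)cc2n1COC(CO)CO`, gives > 100000 nM.

Compound 1 gives the result > 100000 nM, which is a limit of the assay and not a number. Compound 2 gives the result > 100000 nM, which is likewise a limit of the assay and not a number. Compound 2 thus stands at the limit of > 100000 nM in this assay, at which 2 of the 2 values shown sit, and there is no number for it in this assay that would set it apart from anything else measured.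

The next compound, compound 3, has the structure `OCC(CO)OCn1cnc2cc(Cl)c(Cl)cc21`. It differs from compound 2 in one place: hydrogen in place of methylamino on an aromatic carbon. Among the compounds with values here, no step between measured compounds that differ in one place is available, so the size of this change in this assay has no measured counterpart. Since both measured results sit at the limit, no step beyond the scatter is expected in this assay, in either direction. Compound 3 is expected to come out at 100000 nM, within 30000 nM to 300000 nM. This estimate corresponds to an expected step of a number no higher from compound 2 to compound 3 (the limit leaves the size open).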

Compound 3, half-maximal inhibitory concentration: > 100000 nM
Compound 3: only a limit was reported; the forecaster's own chance of this, stated with the estimate: 80%; the middle value sits exactly at the limit.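

No step can be read from compound 2 to compound 3: in this assay both results are limits of the assay, not numbers. The compounds shown leave open what hydrogen in place of methylamino does to inhibition in this assay, and whether compound 1, compound 2 and compound 3 differ from one another at all.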